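Series notes: from compound 2 to compound 3

This account rests on a few compounds, and the source may have more. Where it says the series, first, only, none or still open, it means among the compounds named here.

- compound 1 `CN(CC1CCCCC1)c1cc(C(=O)Nc2ccccc2)ncn1`: 178000 nM
- compound 2 `CN(c1ccccc1)c1cc(C(=O)Nc2ccccc2)ncn1`: "not determined" (no result reported)

Both entries refer to an ADME assay on Vero cells (Chlorocebus sabaeus) for cytotoxicity, read by MTT assay; on this read-out lower numbers stand for stronger inhibition and higher numbers for weaker inhibition. Going by the values given here, compound 2 has no number here, so its standing stays open and the only anchor is compound 1 at 178000 nM. Compound 3 `CN(Cc1ccc(F)cc1)c1cc(C(=O)Nc2ccccc2)ncn1` is still to be measured. The structural change is 4-fluorobenzyl in place of phenyl on a nitrogen on an aromatic ring. Among the compounds with values here, with no measured step to draw on, and compound 1 at 178000 nM as the sole guide, no shift beyond the scatter is expected in this assay, in either direction. Compound 3 is estimated at 150000 nM, with an expected range of 60000 nM to 400000 nM.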

Compound 3, half-maximal inhibitory concentration: 297000 nM
Estimate against measurement, compound 3: 2.0-fold (0.30 log units) below; the range from low to high includes it.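

Swapping cyclohexyl for 4-fluorophenyl on a saturated chain carbon bound to a nitrogen on an aromatic ring gives (a 1.7-fold higher number from compound 1 to compound 3 (0.22 log units; within the scatter)) in (this assay), so at this place an aromatic ring and a saturated ring cannot be told apart on this read-out. The step from compound 2 to compound 3 cannot be read, as compound 2 has no number. No available evidence bears on this result.

Still open, as far as these compounds go, is whether an amine or a carboxylic acid at this place would give a step beyond the scatter. From the compounds shown here alone, the effect of the fluorine alone also remains open, as does that of a longer chain.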